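The compounds below may be only part of what the source reports. "The series", "measured", "known", "first", "only" and "open" are said of these compounds alone.

Measured in a physicochemical assay for lipophilicity, at pH 7.4; on this read-out higher numbers stand for higher lipophilicity and lower numbers for lower lipophilicity:
- compound 1 `Cc1cc(COc2cccc(Cl)c2)nc(-c2ccccn2)n1`: 3.7
- compound 2 `CC(=O)Nc1cccc(OCc2cc(C)nc(-c3ccccn3)n2)c1`: 2.1

Compound 1 holds the higher of the two numbers. For the measured compounds named here, the only measured step, a number 1.60 log units lower from compound 1 to compound 2 (beyond the scatter), is large and beyond the scatter, with acetamido in place of chloro on an aromatic carbon. Compound 3 `Cc1cc(COc2ccc(F)cc2)nc(-c2ccccn2)n1` is not yet measured. The change is 4-fluorophenyl in place of 3-chlorophenyl on an oxygen on a saturated carbon, with 4-fluorophenyl in place of 3-chlorophenyl. Going by the values given here, the measured step also removes chloro, but no measured step brings in fluoro, so it offers only a loose guide. In this assay the estimated step is a number 0.40 log units lower from compound 1 to compound 3 (beyond the scatter), in the same direction but smaller. For compound 3 the estimate is 3.3, with an expected range of 2.9 to 3.7.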

Compound 3, distribution coefficient: 3
Estimate against measurement, compound 3: 0.30 log units above; low and high end bracket the measured number.
By their numbers in this assay, from the lowest: compound 2; then compound 3; then compound 1.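

In this assay, the step on this oxygen-bound aryl group is a number 0.70 log units lower from compound 1 to compound 3 (beyond the scatter), so a halogen exchange alone, with no amide brought in, moves the number beyond the scatter. The leaving and entering groups match in heavy-atom count and in hydrogen-bond donors and acceptors, so these counts do not track the step. No measurement on hand explains the step.

The exchange alters both the halogen and its place on the ring, and these two remain inseparable. Also open, on these data alone, is how 4-chlorophenyl, or a phenyl carrying an amine or a carboxylic acid, would read here.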